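Fluoro in place of propyl on the aryl amide

The source may hold more compounds than are shown below. What is called first, only, known or untested is meant among the compounds shown, and "the series" means these compounds.

Compound 2 `CCCc1ccc(C(=O)Nc2cccc(NC(=O)COc3ccc4c(=O)ccoc4c3)c2)cc1` gives 14 nM in an assay on isolated protein for inhibition of Rho-associated protein kinase 2 (Homo sapiens), read by scintillation counting, radiometric assay and 33P incorporation, with a stated time of 40 min, in the presence of a further agent that is not named here (on this read-out lower numbers stand for stronger inhibition and higher numbers for weaker inhibition), and stands at the lowest of the two numbers measured. Compound 1 `CCCC(=O)Nc1cccc(NC(=O)COc2ccc3c(=O)ccoc3c2)c1` gives 176 nM in this assay, and the two are separated by a 13-fold lower number from compound 1 to compound 2 (1.10 log units; beyond the scatter), a large step. Compound 3 `O=C(COc1ccc2c(=O)ccoc2c1)Nc1cccc(NC(=O)c2ccc(F)cc2)c1` differs from compound 2 by fluoro in place of propyl on an aromatic carbon, para to a large group. Among the measured compounds shown here, the only measured step, a 13-fold lower number from compound 1 to compound 2 (1.10 log units; beyond the scatter), concerns the exchange of propyl for 4-propylphenyl on the carbonyl carbon; no measured pair varies a substituent on that aromatic ring, so the size of the present step is not anchored by data. Since the gain seen in a 13-fold lower number from compound 1 to compound 2 (1.10 log units; beyond the scatter) came with the aryl amide that compound 3 retains, compound 3 is expected to remain potent, with at most a modest rise in number. Compound 3 is estimated at 30 nM, within 8 nM to 120 nM. That estimate implies a 2.1-fold higher number from compound 2 to compound 3 (0.33 log units; beyond the scatter), a step expected near the scatter.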

Compound 3, half-maximal inhibitory concentration: 54 nM
For compound 3 the middle estimate is 1.8-fold (0.26 log units) below the measured one, within the range that was stated.
By their numbers in this assay, from the lowest: compound 2; then compound 3; then compound 1.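

Varying the aromatic ring itself moves the number (a 3.9-fold higher number from compound 2 to compound 3 (0.59 log units; beyond the scatter)), so in this assay the gain seen with compound 2 does not rest on the aryl amide alone, and the propyl group on that aromatic carbon also counts. Even so, much of the gain survives without the propyl group, since 4-fluorophenyl in place of propyl on the carbonyl carbon still gives a step beyond the scatter (a 3.3-fold lower number from compound 1 to compound 3 (0.51 log units; beyond the scatter)). Nothing measured here gives a reason for either step.

With only propyl and fluoro on this aromatic carbon, no trend across substituents can be read. On these data alone, it remains open whether a longer chain such as pentyl, a methoxy group or an amine there would match compound 2 or go beyond it.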